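Chloro in place of methoxy: working notes

This account rests on a few compounds, and the source may have more. Where it says the series, first, only, none or still open, it means among the compounds named here.

For the measured compounds named here, in an ADME assay on KB cells (Homo sapiens) for cytotoxicity, read by resazurin assay, with a stated time of 72 h (on this read-out higher numbers stand for weaker inhibition and lower numbers for stronger inhibition), compound 1 (`O=C(/C=C/c1cccnc1)c1ccccc1`) gives 7700 nM and compound 2 (`COc1cccc(C(=O)/C=C/c2cccnc2)c1`) gives 2300 nM, the lower of the two numbers so far. Going by the values given here, the only measured step is a 3.3-fold lower number from compound 1 to compound 2 (0.52 log units; beyond the scatter), a modest change beyond the scatter, with methoxy in place of hydrogen on an aromatic carbon. Compound 3 (`O=C(/C=C/c1cccnc1)c1cccc(Cl)c1`) has chloro in place of methoxy on an aromatic carbon, meta to a large group: chloro in place of methoxy on an aromatic carbon. Among the compounds with values here, no measured step covers this exchange directly. Compound 3 keeps a substituent at that carbon, so no return to the level of compound 1 at 7700 nM is expected. The expected change is small and upward, within the scatter, namely a 1.2-fold higher number from compound 2 to compound 3 (0.09 log units; within the scatter). In this assay, compound 3 is estimated at 2800 nM, with an expected range of 1100 nM to 6500 nM.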

Compound 3, half-maximal inhibitory concentration: 12700 nM
The estimate for compound 3 lay 4.5-fold (0.66 log units) below the measured number, outside the stated range (above it).
By their numbers in this assay, from the lowest: compound 2; then compounds 1 and 3 (each within the scatter of the next).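

At this carbon, meta to a large group, the lower number seen with methoxy does not carry over to chloro: in this assay the exchange gives a 5.5-fold higher number from compound 2 to compound 3 (0.74 log units; beyond the scatter), so the identity of the substituent matters here, not merely its presence. Chloro in place of hydrogen gives a 1.6-fold higher number from compound 1 to compound 3 (0.22 log units; within the scatter), which leaves chloro not separated from hydrogen at this carbon, and among the three compounds only methoxy stands apart. Nothing measured accounts for the difference between methoxy and chloro.

Still open, on these data alone, is whether the level of compound 2 is particular to methoxy or is shared by a hydroxy group, an ethoxy chain or an amine at this carbon. Also open, as far as these compounds go, is whether methoxy on another carbon of this ring gives a step of similar size.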